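Second Fluoro Group on the Ring of Compound 3

A few compounds are considered here, and "the series" means these few. Any claim that something is new, unique, unknown or untested is made for them only; others in the source may bear on it.

compound 1 `COc1ccc(CN2CCC(CCNC(=O)/C=C/c3cc(C(C)(C)C)c(O)c(C(C)(C)C)c3)CC2)cc1` 72500 nM
compound 2 `Cc1ccccc1CN1CCC(CCNC(=O)/C=C/c2cc(C(C)(C)C)c(O)c(C(C)(C)C)c2)CC1` 69300 nM
compound 3 `CC(C)(C)c1cc(/C=C/C(=O)NCCC2CCN(Cc3ccc(F)cc3)CC2)cc(C(C)(C)C)c1O` 59600 nM

In an assay on isolated protein for inhibition of Amine oxidase [flavin-containing] A (Homo sapiens), read by fluorescence, with stated times of 15 min and 20 min (a lower number here means a stronger inhibitor, a higher number a weaker inhibitor), compound 1 gives 72500 nM, compound 2 gives 69300 nM, and compound 3 gives 59600 nM. Compound 3 shows the lowest of the three numbers, yet the steps of a 1.2-fold lower number from compound 1 to compound 3 (0.09 log units; within the scatter) and a 1.2-fold lower number from compound 2 to compound 3 (0.07 log units; within the scatter) both lie within the scatter, so no order among the three can be read. Compound 4 `CC(C)(C)c1cc(/C=C/C(=O)NCCC2CCN(Cc3ccc(F)cc3F)CC2)cc(C(C)(C)C)c1O` differs from compound 3 by fluoro in place of hydrogen on an aromatic carbon. The step that bears on it most closely is the swap of one group on this ring, and that step stayed within the scatter, as did a 1.0-fold lower number from compound 1 to compound 2 (0.02 log units; within the scatter). For the measured compounds named here, no measured step adds a second group to this ring. The expected step of a 1.1-fold lower number from compound 3 to compound 4 (0.03 log units; within the scatter) is therefore none beyond the scatter. Compound 4 is estimated at 55000 nM, within a range from 25000 nM to 120000 nM.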

Compound 4, half-maximal inhibitory concentration: 70600 nM
The estimate for compound 4 lay 1.3-fold (0.11 log units) below the measured number; measured number inside the range.
By their numbers in this assay, from the lowest: compounds 3, 2, 4 and 1 (each within the scatter of the next).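

Adding a second fluoro, ortho to a large group and meta to the first fluoro, gives a 1.2-fold higher number from compound 3 to compound 4 (0.07 log units; within the scatter) in this assay, so this position takes the extra fluorine atom with no readable change. For the compounds shown here, the 2,4-difluorophenyl group also stays level with the groups of the earlier compounds, as a 1.0-fold higher number from compound 2 to compound 4 (0.01 log units; within the scatter) and a 1.0-fold lower number from compound 1 to compound 4 (0.01 log units; within the scatter) show. Nothing measured here offers a reason for this result.
Going by these compounds, whether an amine or a carboxylic acid at this same place would give a step beyond the scatter stays open. So does whether any group on this ring can move the number at all.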